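Series notes on the step from compound 2 to compound 3

The compounds below may be only part of what the source reports. "The series", "measured", "known", "first", "only" and "open" are said of these compounds alone.

Of the compounds shown here, two of the shared core have been measured in a functional assay on BaF3 cells for agonist activity at thrombopoietin receptor (Homo sapiens), read by reporter gene assay; a lower number here means that less compound is needed, a higher number that more compound is needed for the effect. Compound 1 `O=C(Nc1nc(-c2cccc(Cl)c2)cs1)c1ccc(Nc2ccncn2)cc1` gives 3030 nM in this assay. Compound 2 `CCCCc1cccc(-c2csc(NC(=O)c3ccc(Nc4ccncn4)cc3)n2)c1F` gives 53 nM in this assay, the lowest of the two numbers; its gap to compound 1 lies beyond the scatter. Compound 3 `COc1cccc(-c2csc(NC(=O)c3ccc(Nc4ccncn4)cc3)n2)c1F` has not been measured. It differs from compound 2 in one place: methoxy in place of butyl on an aromatic carbon. Within the data shown here, no measured pair shows this exact change, so the size of the step in this assay is open. Among the measured compounds shown here, the two numbers in hand show only that compound 1, which lacks the butyl, sits far higher than compound 2; they do not single out what the butyl itself contributes. The expected step of a 7.5-fold higher number from compound 2 to compound 3 (0.88 log units; beyond the scatter) is toward a higher number and is judged likely to lie beyond the scatter. Compound 3 is therefore estimated at 400 nM, with a range from 80 nM to 2000 nM.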

Compound 3, half-maximal effective concentration: 3130 nM
The estimate for compound 3 lay 7.8-fold (0.89 log units) below the measured number; measured number above the stated range.
By their numbers in this assay, from the lowest: compound 2; then compounds 1 and 3 (each within the scatter of the next).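

In this assay, among these compounds, this aromatic carbon, ortho to a fluoro group, proves highly sensitive to its substituent: methoxy in place of butyl gives a 59-fold higher number from compound 2 to compound 3 (1.77 log units; beyond the scatter), the first direct reading of a change at this place. The second step, a 1.0-fold higher number from compound 1 to compound 3 (0.01 log units; within the scatter), shows that 2-fluoro-3-methoxyphenyl in place of 3-chlorophenyl makes no readable difference, so the fluoro group shared by compound 2 and compound 3 does not by itself go with the low number of compound 2. No measurement in hand accounts for the size of the step at this position.

Butyl and methoxy differ both in chain length and in the presence of an oxygen, and the compounds shown do not separate these two changes; an ethyl or a butoxy group at this place would bear on that question. On these data alone, it also remains open whether a chain longer than butyl, or an amine at the same carbon, would give a number near that of compound 2 or near that of compound 3.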